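Moving the nitrile on a thiazole ester: cytotoxicity outlook

This account rests on a few compounds, and the source may have more. Where it says the series, first, only, none or still open, it means among the compounds named here.

Compound 1 `CCOC(=O)c1nc(C2CCCCC2)sc1-c1cccc(C#N)c1`: > 50 ug/mL (a limit)
Compound 2 `CCOC(=O)c1nc(C(C)C)sc1-c1cnc2ccccc2c1`: > 50 ug/mL (a limit)

In an ADME assay on CHO-K1 cells (Cricetulus griseus) for cytotoxicity, read by MTT assay, with a stated time of 24 h (on this read-out higher numbers stand for weaker inhibition and lower numbers for stronger inhibition), compound 1 gives > 50 ug/mL, which is a limit of the assay and not a number. Compound 2 likewise reaches only a limit, > 50 ug/mL. Both values sit at the limit of > 50 ug/mL in this assay, at which 2 of the 2 values shown sit. Compound 3 `CCOC(=O)c1nc(C2CCCCC2)sc1-c1ccccc1C#N` is not yet measured; it differs from compound 1 by 2-cyanophenyl in place of 3-cyanophenyl on an aromatic carbon. Without a measured step between two compounds of this kind, the step is expected to be none beyond the scatter: a number no higher from compound 1 to compound 3 (the limit leaves the size open). Compound 3 is therefore estimated at 50 ug/mL, between 30 ug/mL and 90 ug/mL, most likely again reported as a limit.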

Compound 3, half-maximal inhibitory concentration: > 50 ug/mL
Compound 3: no number, only a limit; the forecaster's own chance of this, stated with the estimate: 85%; the middle value sits exactly at the limit.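

Compound 1 and compound 3 both stop at a limit of the assay, so no step between them can be read: the limit of > 50 ug/mL in this assay, at which 3 of the 3 values shown sit.

The compounds shown leave open whether 2-cyanophenyl and 3-cyanophenyl differ at all in this assay, since none of them gives an actual number.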